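Compound 4 against the limit value of compound 3

The source may report more compounds than this note shows. Statements on the series, on what has been measured and on what is new or still open speak of the compounds shown alone.

Values in an ADME assay on L6 cells (Rattus norvegicus) for cytotoxicity; on this read-out higher numbers stand for weaker inhibition and lower numbers for stronger inhibition:
- compound 1 `O=C(Nc1c(O)cccc1-c1nc2c(C(=O)O)cccc2o1)c1ccccn1`: 30600 nM
- compound 2 `O=C(Nc1c(O)cccc1-c1nc2c(C(=O)O)cccc2o1)c1ccc(F)c(F)c1F`: 210000 nM
- compound 3 `O=C(Nc1c(O)cccc1-c1nc2c(C(=O)O)cccc2o1)c1ccccc1`: > 240000 nM (a limit, not a number)
- compound 4 `O=C(Nc1c(O)cccc1-c1nc2c(C(=O)O)cccc2o1)c1cc2ccccc2[nH]1`: not yet measured

Compound 3 gives only a limit, > 240000 nM. Across the series, this is the limit of > 240000 nM in this assay, at which 1 of the 3 values shown sits.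

The change to compound 4 is 1H-indol-2-yl in place of phenyl on a carbonyl carbon. In short, 1H-indol-2-yl takes the place of phenyl on a carbonyl carbon whose other neighbour is an amide-type nitrogen.

Three measured steps change this same group. The first is an at least 7.8-fold higher number from compound 1 to compound 3 (0.89 log units; beyond the scatter), and the second is a 6.9-fold higher number from compound 1 to compound 2 (0.84 log units; beyond the scatter). The third is an at least 1.1-fold higher number from compound 2 to compound 3 (0.05 log units; that floor lies within the scatter), so compound 2 and compound 3 are not separated in this assay. Swaps at this place have therefore given modest steps at most where a size can be read, and only compound 1 stands clearly lower than the other two. The new group has not been tried in the series, and the starting point is a limit, so a large step is not expected. The expected step is an at least 1.8-fold lower number from compound 3 to compound 4 (0.26 log units; that floor lies within the scatter), a modest move towards a lower number. For compound 4 the estimate is 130000 nM, with an expected range of 40000 nM to 240000 nM.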

Compound 4, half-maximal inhibitory concentration: 212000 nM
For compound 4 the middle estimate is 1.6-fold (0.21 log units) below the measured one; low and high end bracket the measured number.
By their numbers in this assay, from the lowest: compound 1; then compounds 2 and 4 (each within the scatter of the next). At a limit, above all of these: compound 3.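

In this assay, 1H-indol-2-yl on the carbonyl carbon is not separated from 2,3,4-trifluorophenyl, with a 1.0-fold higher number from compound 2 to compound 4 (0.00 log units; within the scatter), even though it brings 9 heavy atoms and a hydrogen-bond donor to this place. The gap to pyridin-2-yl remains, with a 6.9-fold higher number from compound 1 to compound 4 (0.84 log units; beyond the scatter), so a hetero atom in an aromatic ring at this place does not by itself go with the lower number, since compound 4 carries one as well and compound 1 remains the only one of the four that stands clearly lower. With a limit rather than a number on one side, an at least 1.1-fold lower number from compound 3 to compound 4 (0.05 log units; that floor lies within the scatter) does not separate that pair: the limit of > 240000 nM in this assay, at which 1 of the 4 values shown sits.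

On these data alone, it remains open whether the lower number of compound 1 is specific to pyridin-2-yl, and pyridin-3-yl or pyridin-4-yl on the same carbonyl carbon would test that directly. The compounds shown also leave open how far the numbers in this assay depend on the carboxylic acid of the shared core, as all four carry it and none has a methyl ester in its place.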